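Fluorine Moved on the Pendant Ring of Compound 1

A few compounds are considered here, and "the series" means these few. Any claim that something is new, unique, unknown or untested is made for them only; others in the source may bear on it.

Compound 1 `COc1cc(CCc2ccccc2)cc(OC)c1O` gives 530 nM in a functional assay on HCT-116 cells (Homo sapiens) for antiproliferative activity, read by MTT assay, with a stated time of 72 h (on this read-out higher numbers stand for weaker inhibition and lower numbers for stronger inhibition), and holds the lowest of the two numbers measured; its nearest neighbour, compound 2 `COc1cc(CCc2ccc(F)cc2)cc(OC)c1O`, gives 1190 nM. For the measured compounds named here, the step of a 2.2-fold higher number from compound 1 to compound 2 (0.35 log units; beyond the scatter) is the only measured change that bears on the new compound. Compound 3 `COc1cc(CCc2cccc(F)c2)cc(OC)c1O` differs from compound 1 by fluoro in place of hydrogen on an aromatic carbon. Because a 2.2-fold higher number from compound 1 to compound 2 (0.35 log units; beyond the scatter) was modest yet beyond the scatter, a step of similar direction, a 1.6-fold higher number from compound 1 to compound 3 (0.21 log units; within the scatter), is expected for compound 3. Compound 3 is therefore estimated at 850 nM, within 420 nM to 1700 nM.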

Compound 3, half-maximal inhibitory concentration: 7570 nM
The estimate for compound 3 lay 8.9-fold (0.95 log units) below the measured number; measured number outside the range, above it.
By their numbers in this assay, from the lowest: compound 1; then compound 2; then compound 3.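

In this assay, the same replacement of hydrogen by fluoro gives a much larger step when the fluoro sits meta to a large group, a 14-fold higher number from compound 1 to compound 3 (1.15 log units; beyond the scatter), than the earlier 2.2-fold higher number from compound 1 to compound 2 (0.35 log units; beyond the scatter). The size of the loss therefore depends on where the fluoro stands on this aromatic ring, although both placements raise the number. Nothing available accounts for this difference between the two placements. Going by these compounds, whether a methoxy group or an amine at this position would also raise the number, or would bring it back towards that of compound 1, remains open.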